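One Methyl Fewer, With the Series at Its Limit

The source may report more compounds than this note shows. Statements on the series, on what has been measured and on what is new or still open speak of the compounds shown alone.

In a functional assay on MDA-MB-435 cells (Homo sapiens) (on this read-out higher numbers stand for weaker inhibition of growth and lower numbers for stronger inhibition of growth), compound 1 `COc1cccc(-c2cc(O)c3c(C)cc(C)nc3n2)c1` gives < 10 nM, which is a limit of the assay and not a number. Compound 2 `COc1cccc(-c2cc(O)c3cc(C)cnc3n2)c1` gives < 10 nM, again a limit. Compound 3 `COc1cccc(-c2cc(O)c3c(C)ccnc3n2)c1` gives < 10 nM, also a limit, so its standing is known only as a limit and not as a number. The whole set so far rests on (the limit of < 10 nM in this assay, at which 3 of the 3 values shown sit).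

Compound 4 `COc1cccc(-c2cc(O)c3cccnc3n2)c1` differs from compound 3 by hydrogen in place of methyl on an aromatic carbon. This is hydrogen in place of methyl on an aromatic carbon, on a six-membered aromatic ring with 1 nitrogen, opposite the ring nitrogen.

One measured step is of the same kind: a step that the two limits leave unreadable from compound 1 to compound 3. Among the compounds with values here, it offers no size to carry over and no direction, and the values of compound 2 add no step. On that basis, no step beyond the scatter is expected in this assay, though the data cannot rule one out. The expected change is a step that the limit leaves unreadable from compound 3 to compound 4, and this is an estimate only. Compound 4 is estimated at 9 nM, with an expected range from 3 nM to 40 nM.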

Compound 4, concentration for 50% growth inhibition: < 10 nM
Compound 4 ended at the assay's limit; the forecaster's own chance of this, stated with the estimate: 60%; the middle value does not contradict the limit.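

The steps to compound 4 from compound 2 and from compound 3 cannot be read, since these compounds share a single limit in this assay: the limit of < 10 nM in this assay, at which 4 of the 4 values shown sit. The compounds shown leave open how strongly each one actually inhibits growth, and whether hydrogen in place of methyl changes that inhibition at all.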